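Inverting one ring stereocentre between compound 3 and compound 4

A few compounds are considered here, and "the series" means these few. Any claim that something is new, unique, unknown or untested is made for them only; others in the source may bear on it.

The series is judged in an assay on Sf9 cells for inhibition of histone deacetylase 11 (Homo sapiens), read by fluorescence, tested at 0.5 uM; on this read-out lower numbers stand for less inhibition and higher numbers for more inhibition at the one concentration tested (going by the name of the read-out). Compound 1, `O=C(NO)c1cccc(-c2cn([C@@H]3C[C@@H](CO)N(CCCc4ccccc4)C3)nn2)c1`, gives in this assay only a limit, < 10%. Compound 2, `O=C(/C=C/c1cn([C@@H]2C[C@@H](CO)N(Cc3ccccc3)C2)nn1)NO`, likewise returns only a limit, < 10%. Within the data shown here, compound 3, `O=C(/C=C/c1cn([C@H]2C[C@@H](CO)N(CCCc3ccccc3)C2)nn1)NO`, is the single member with a number: in this assay compound 3 gives 31%. Among the measured compounds shown here, compound 3 therefore stands alone as the one measured value, the other two entries sitting at the assay limit, as noted in the limit of < 10% in this assay, at which 2 of the 3 values shown sit.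

The next compound, compound 4, `O=C(/C=C/c1cn([C@@H]2C[C@@H](CO)N(CCCc3ccccc3)C2)nn1)NO`, is to be measured in this assay. Its relation to compound 3 is purely stereochemical: the two compounds have the same atoms and bonds and differ only in configuration as drawn: 1 of 3 stereo elements differ; a stereocentre at a saturated ring carbon is drawn S in compound 3 and R in compound 4.

For the measured compounds named here, no step between two measured compounds in this set is available to calibrate what such an inversion does, so the size and direction of the step are open. Given that two of three entries sit at the limit, per (the limit of < 10% in this assay, at which 2 of the 3 values shown sit), the estimated step from compound 3 to compound 4 is a number 16 percentage points lower from compound 3 to compound 4 (beyond the scatter), a drop that may itself be within the scatter. Compound 4 is accordingly expected at about 15%, estimated between 0% and 35%, with a real chance the assay reports only a limit.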

Compound 4, a percentage reported as inhibition, at one concentration (the size of the read-out at that concentration, not a potency): 13%
The estimate for compound 4 lay 2 percentage points above the measured number; low and high end bracket the measured number.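

Among these compounds, compound 3 and compound 4 form the first readable pair at this saturated ring carbon in this assay. Inverting the stereocentre from S to R gives a number 18 percentage points lower from compound 3 to compound 4 (beyond the scatter), a modest step. The step can be assigned to this one stereocentre, with no change of group involved, because the comparison is purely one of configuration: the fact that compounds 3 and 4 differ only in the configuration as drawn The number in this assay is therefore higher with the S drawing at this position in this pair. Phenethyl in place of phenyl on a saturated chain carbon bound to an amine nitrogen in a ring gives a number at least 3 percentage points higher from compound 2 to compound 4 (that floor lies within the scatter). 2-(Hydroxycarbamoyl)ethenyl in place of 3-(hydroxycarbamoyl)phenyl on an aromatic carbon gives a number at least 3 percentage points higher from compound 1 to compound 4 (that floor lies within the scatter). The new value therefore adds nothing firm on these other two changes: the limit of < 10% in this assay, at which 2 of the 4 values shown sit.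

On these data alone, whether the higher number with the S drawing holds with another substituent remains open, for example a longer chain on the amine nitrogen in the ring, or an amine or a carboxylic acid in place of the hydroxymethyl group. Also open, as far as these compounds go, is how far this difference at a single concentration carries over to potency, and what inverting the other ring stereocentre does in this assay.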